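From 2,4-dichlorophenyl to 3,5-dibromophenyl on a carbonyl carbon

A few compounds are considered here, and "the series" means these few. Any claim that something is new, unique, unknown or untested is made for them only; others in the source may bear on it.

Compound 1 `Cc1ccc(C(=O)Nc2cc(Cl)ccc2OCC(=O)Nc2ccc(S(N)(=O)=O)cc2C)c(C)c1` gives 47600 nM
Compound 2 `Cc1ccc(C)c(C(=O)Nc2cc(Cl)ccc2OCC(=O)Nc2ccc(S(N)(=O)=O)cc2C)c1` gives 79700 nM
Compound 3 `Cc1cc(S(N)(=O)=O)ccc1NC(=O)COc1ccc(Cl)cc1NC(=O)c1ccc(Cl)cc1Cl` gives 61100 nM

All three were read in a functional assay on C8166 cells (Homo sapiens) for cytotoxicity, read by MTT assay (on this read-out higher numbers stand for lower toxicity in this test and lower numbers for higher toxicity in this test), and compound 3 stands within the scatter of both others, so no order among them can be drawn. Compound 4 `Cc1cc(S(N)(=O)=O)ccc1NC(=O)COc1ccc(Cl)cc1NC(=O)c1cc(Br)cc(Br)c1` differs from compound 3 by one change, 3,5-dibromophenyl in place of 2,4-dichlorophenyl on a carbonyl carbon with 3,5-dibromophenyl in place of 2,4-dichlorophenyl on a carbonyl carbon. Three measured steps at this same place bear on it: a 1.3-fold higher number from compound 1 to compound 3 (0.11 log units; within the scatter) and a 1.3-fold lower number from compound 2 to compound 3 (0.12 log units; within the scatter) and also a 1.7-fold higher number from compound 1 to compound 2 (0.22 log units; within the scatter) are all small. None of them involves bromine, so the guidance is indirect. No step beyond the scatter is expected in this assay here. The estimated value for compound 4 is 58000 nM with an expected range from 26000 nM to 125000 nM as its span.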

Compound 4, half-maximal cytotoxic concentration: 89700 nM
Estimate against measurement, compound 4: 1.5-fold (0.19 log units) below; the range from low to high includes it.
By their numbers in this assay, from the lowest: compounds 1, 3, 2 and 4 (each within the scatter of the next).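

In this assay, going by these compounds alone, the first bromine-bearing group at this place, on a carbonyl carbon, gives no step beyond the scatter: a 1.5-fold higher number from compound 3 to compound 4 (0.17 log units; within the scatter), a 1.1-fold higher number from compound 2 to compound 4 (0.05 log units; within the scatter) and a 1.9-fold higher number from compound 1 to compound 4 (0.28 log units; within the scatter). The four aryl groups on this carbonyl carbon thus cannot be told apart in this test, and the range of substituents that shows this now includes bromine as well as chlorine and methyl.

The compounds shown leave open whether a phenyl ring carrying an amine or a carboxylic acid would give a step beyond the scatter. They also leave open whether replacing the phenyl ring with a saturated ring or a longer alkyl chain would do so. No evidence on the cause of these readings is at hand.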